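The compounds below may be only part of what the source reports. "The series", "measured", "known", "first", "only" and "open" are said of these compounds alone.

In an ADME assay on Caco-2 cells (Homo sapiens) for permeability, read by LC-MS, in the apical to basolateral direction, with a stated time of 2 h, tested at 2 uM (a lower number here means that the compound crosses the layer more slowly, a higher number that the compound crosses the layer faster), compound 1 `CC[C@@H](Nc1c(C#N)c(-c2ccc(-c3ccc(OC)cc3)cc2)nc2cnccc12)C(N)=O` gives 114 nm/s and compound 2 `CN(CC(N)=O)c1c(C#N)c(-c2ccc(Br)cc2)nc2cnccc12` gives 206 nm/s. Among the measured compounds shown here, these two numbers lie within the usual scatter of each other, so compound 1 sits level with the only other measured compound. Compound 3 `CC[C@@H](Nc1c(C#N)c(-c2ccc(-c3ccccc3OC)cc2)nc2cnccc12)C(N)=O` keeps the atoms of compound 1 but joins them differently, with 2-methoxyphenyl in place of 4-methoxyphenyl on an aromatic carbon, para to a large group (2-methoxyphenyl in place of 4-methoxyphenyl on an aromatic carbon). For the measured compounds named here, no measured pair of compounds differs in one place, so the data offer no direct guide to this change. In this assay, no step beyond the scatter is therefore expected, and the starting point is compound 1 at 114 nm/s. The estimated step of a 1.2-fold higher number from compound 1 to compound 3 (0.09 log units; within the scatter) stays within that scatter. For compound 3 the expected value is 140 nm/s, with an estimated range from 65 nm/s to 290 nm/s.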

Compound 3, apparent permeability: 160 nm/s
Estimate against measurement, compound 3: 1.1-fold (0.06 log units) below; the measured number falls inside the stated range.
By their numbers in this assay, from the lowest: compounds 1, 3 and 2 (each within the scatter of the next).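

In this assay, among the compounds shown here, 2-methoxyphenyl in place of 4-methoxyphenyl gives the first step that can be read between compounds differing in one place, a 1.4-fold higher number from compound 1 to compound 3 (0.15 log units; within the scatter), and that step concerns an aromatic carbon para to a large group. With the same atoms joined differently, this read-out therefore does not separate the two methoxyphenyl arrangements on the shared core. No measured evidence bears on this result.

From the compounds shown here alone, how 3-methoxyphenyl, or an amine or a carboxylic acid on that ring, would read in this assay remains open, as does whether a larger step can arise at this position at all. Compound 2 differs from compound 1 in more than one place, so it gives no guide to any single one of these changes.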